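Replacing the (morpholin-4-yl)carbonyl group of compound 3

The source may report more compounds than this note shows. Statements on the series, on what has been measured and on what is new or still open speak of the compounds shown alone.

Measured in a functional assay with Oryctolagus cuniculus as the target; a lower number here means a stronger inhibitor, a higher number a weaker inhibitor:
- compound 1 `CC/N=C(/N)Nc1nc(-c2ccc(OC)cc2)c(-c2ccc(OC)cc2)s1` gives > 100 nM (a limit)
- compound 2 `COc1ccc(-c2nc(CNC(=O)CSC)sc2-c2ccc(OC)cc2)cc1` gives < 100 nM (a limit)
- compound 3 `COc1ccc(-c2nc(C(=O)N3CCOCC3)sc2-c2ccc(OC)cc2)cc1` gives < 10 nM (a limit)

Compound 3 stands at < 10 nM in this assay as a limit, not a number. Compound 4 `CCOC(=O)/C(C#N)=C/c1nc(-c2ccc(OC)cc2)c(-c2ccc(OC)cc2)s1` carries 2-cyano-2-(ethoxycarbonyl)ethenyl in place of (morpholin-4-yl)carbonyl (2-cyano-2-(ethoxycarbonyl)ethenyl in place of (morpholin-4-yl)carbonyl on an aromatic carbon) on the same aromatic carbon. The most telling step is an at least 10-fold lower number from compound 1 to compound 3 (1.00 log units; beyond the scatter), at least modest in size, so a swap at this carbon can move the number considerably. Going by these compounds, the other two, a number no higher from compound 1 to compound 2 (the limit leaves the size open) and a step that the two limits leave unreadable from compound 2 to compound 3, stay open in size. The step expected is an at least 3.0-fold higher number from compound 3 to compound 4 (0.47 log units; beyond the scatter) by estimate, toward a weaker inhibitor. Compound 4 is estimated at 30 nM (expected range 4 nM to 200 nM).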

Compound 4, half-maximal inhibitory concentration: < 10 nM
Compound 4: only a limit was reported; the forecaster's own chance of this, stated with the estimate: 75%; at least 3.0-fold (0.47 log units) between middle value and limit.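

In this assay compound 4 gives < 10 nM, a limit and not a number. A ring in the group on this aromatic carbon is therefore not required to reach this limit: the open-chain 2-cyano-2-(ethoxycarbonyl)ethenyl group still gives an at least 10-fold lower number from compound 1 to compound 4 (1.00 log units; beyond the scatter). The steps to compound 4 from compound 2 and compound 3 cannot be read, and compound 3 and compound 4 cannot be ranked: the limit of < 10 nM in this assay, at which 2 of the 4 values shown sit.

Going by these compounds, how far the true values of compound 3 and compound 4 lie past their shared limit stays open. So does whether a carboxylic acid or an amine on this carbon would reach the same limit.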